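This account rests on a few compounds, and the source may have more. Where it says the series, first, only, none or still open, it means among the compounds named here.

Measured compounds in a functional assay on HepG2 cells (Homo sapiens) for antiproliferative activity, read by MTT assay, with a stated time of 24 h; on this read-out higher numbers stand for weaker inhibition and lower numbers for stronger inhibition:

- compound 1 `COc1ccc(C2CC(c3ccccc3)=NN2c2ccc(-c3ccccc3)nn2)cc1`: > 100000 nM, a limit of the assay, not a number
- compound 2 `COc1ccc(C2CC(c3ccc(Cl)cc3)=NN2c2ccc(-c3ccccc3)nn2)cc1`: > 100000 nM, again a limit, not a number
- compound 3 `COc1ccc(C2=NN(c3ccc(-c4ccccc4)nn3)C(c3ccc(F)cc3)C2)cc1`: 9160 nM

Among the measured compounds shown here, compound 3 thus carries the only number in this assay; the other two values sit at the limit of > 100000 nM in this assay, at which 2 of the 3 values shown sit. For the measured compounds named here, the single measured step, a step that the two limits leave unreadable from compound 1 to compound 2, runs between two limits and its size cannot be read.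

Compound 4 `COc1ccc(C2=NN(c3ccc(-c4ccccc4)nn3)C(c3ccc(OC)cc3)C2)cc1` differs from compound 3 by methoxy in place of fluoro on an aromatic carbon. Going by the values given here, no measured step covers an exchange of this kind, and the one step available gives no size. The step of a 1.3-fold higher number from compound 3 to compound 4 (0.12 log units; within the scatter) is therefore expected to stay within the usual scatter, in no particular direction. Compound 4 is estimated at 12000 nM, with a range from 3500 nM to 45000 nM.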

Compound 4, half-maximal inhibitory concentration: > 100000 nM
Compound 4: no number, only a limit; the forecaster's own chance of this, stated with the estimate: 30%; middle value at least 8.3-fold (0.92 log units) from the limit.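

In this assay, among the compounds shown here, the change from 4-fluorophenyl to 4-methoxyphenyl gives the first readable step, an at least 10-fold higher number from compound 3 to compound 4 (1.03 log units; beyond the scatter), showing that the group at this place on the aromatic ring matters. Compound 4 gives > 100000 nM, which is a limit, not a number. The steps to compound 4 from compound 1 and compound 2 cannot be read, since both ends are limits: the limit of > 100000 nM in this assay, at which 3 of the 4 values shown sit.

Still open, on these data alone, is whether any group other than fluoro at this place keeps a measurable value. A hydroxyl, an amine or a nitrile there would test this.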